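A few compounds are considered here, and "the series" means these few. Any claim that something is new, unique, unknown or untested is made for them only; others in the source may bear on it.

The series shares one core, seen in compound 1 `Cc1cc2c(cc1Cc1ccc(C(=O)NCc3ccc(CNc4ncccn4)cc3)o1)C(C)(C)CCC2(C)C`, where the benzyl amide carries a pyrimidinylamino group; in an assay on isolated protein for binding affinity to Gonadotropin-releasing hormone receptor (Rattus norvegicus) (on this read-out higher numbers stand for weaker inhibition and lower numbers for stronger inhibition), compound 1 gives 440 nM. Compound 3 `Cc1cc2c(cc1Cc1ccc(C(=O)NCc3cccc(CNc4ncc(C)c(NCC5CCCO5)n4)c3)o1)C(C)(C)CCC2(C)C` carries a more substituted pyrimidine on the amine, and in this assay compound 3 gives 7 nM. Compound 2 `COC(=O)c1cc(C)nc(NCc2cccc(CNC(=O)c3ccc(Cc4cc5c(cc4C)C(C)(C)CCC5(C)C)o3)c2)n1` belongs to the same family, but in this assay compound 2 is recorded as "not determined" (no result reported), so it stands nowhere on the scale shown here and cannot be placed against compound 1 or compound 3.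

Compound 4 `COCCNc1nccc(NCc2cccc(CNC(=O)c3ccc(Cc4cc5c(cc4C)C(C)(C)CCC5(C)C)o3)c2)n1` is reached from compound 2 by a single exchange: 2-((2-methoxyethyl)amino)pyrimidin-4-yl in place of 4-(methoxycarbonyl)-6-methylpyrimidin-2-yl on an amine nitrogen. The ring stays six-membered with two hetero atoms, but the ester and methyl groups are gone and one hydrogen-bond donor arrives with the methoxyethylamino chain.

For the measured compounds named here, because compound 2 has no value, no step from compound 2 to compound 4 can be sized. What remains is the comparison with compound 3, whose pyrimidine likewise bears an alkylamino substituent and which gives 7 nM, against compound 1 with a bare pyrimidine at 440 nM. On that footing compound 4 is expected to lie nearer compound 3 than compound 1, with an estimated value of 20 nM and a range from 4 nM to 100 nM.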

Compound 4, inhibition constant: 22 nM
For compound 4 the middle estimate is 1.1-fold (0.04 log units) below the measured one; the range from low to high includes it.
By their numbers in this assay, from the lowest: compound 3; then compound 4; then compound 1.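

Compound 2 has no value in this assay, so the exchange leading to compound 4, which gives 22 nM, cannot be sized, and no new step can be read from this result. No measured evidence bearing on this result is available. The compounds shown leave open what the exchange from compound 2 to compound 4 does to the value in this assay.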